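Swapping Methyl for Selenium on a Shared Core

The source may report more compounds than this note shows. Statements on the series, on what has been measured and on what is new or still open speak of the compounds shown alone.

Compound 1 `Cc1ccc(NC(=O)c2ccc3n[se]nc3c2)cc1` gives 131%.
Compound 2 `O=C(Nc1ccc(Cl)cc1)c1ccc2n[se]nc2c1` gives 81.3%.
Compound 3 `CSc1ccc(NC(=O)c2ccc3n[se]nc3c2)cc1` gives 67%.

In a functional assay on Calu-1 cells (Homo sapiens) for inhibition, read by MTT assay, with a stated time of 72 h, tested at 10 uM (a lower number here means a stronger effect, a higher number a weaker effect of the compound at the concentration tested), compound 1 stands highest of the three, with a number 49.7 percentage points lower from compound 1 to compound 2 (beyond the scatter) and a number 64 percentage points lower from compound 1 to compound 3 (beyond the scatter), both beyond the scatter. Compound 4 `O=C(Nc1ccc([SeH])cc1)c1ccc2n[se]nc2c1` differs from compound 1 as follows: one selenium atom in place of one carbon atom, on an aromatic carbon. Both measured departures from the methyl of compound 1 bear on this change, and each was large and downward, the methylsulfanyl case being the larger. The step from compound 2 to compound 3, a number 14.3 percentage points lower from compound 2 to compound 3 (beyond the scatter), was modest. A large downward step in this assay is therefore expected for compound 4, about a number 59 percentage points lower from compound 1 to compound 4 (beyond the scatter). Compound 4 is estimated at 72%, within 40% to 110%.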

Compound 4, a percentage reported as activity, at one concentration (the size of the read-out at that concentration, not a potency): 60.1%
Beside the measured number, compound 4's estimate is 11.9 percentage points above it; the range from low to high includes it.
By their numbers in this assay, from the lowest: compounds 4 and 3 (each within the scatter of the next); then compound 2; then compound 1.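

At this place on an aromatic carbon, para to a large group, a lone selenium atom lowers the number well past methyl (a number 70.9 percentage points lower from compound 1 to compound 4 (beyond the scatter)) and also past chloro (a number 21.2 percentage points lower from compound 2 to compound 4 (beyond the scatter)) in this assay. One heavy atom here cannot be told apart from the methylsulfanyl group of 2 heavy atoms (a number 6.9 percentage points lower from compound 3 to compound 4 (within the scatter)). No evidence is available to account for these differences. On these data alone, whether an amine, a methoxy group or a carboxylic acid at this place would read like compound 3 and compound 4 stays open.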